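The source may report more compounds than this note shows. Statements on the series, on what has been measured and on what is new or still open speak of the compounds shown alone.

Three compounds anchor this account. Compound 1 `Cc1nc(C)n(CC(=O)N2CCN(c3sc(C(F)(F)F)nc3-c3nc4ccc(OC5CNC5)cc4[nH]3)C[C@H]2C)n1` gives 580 nM in a functional assay on Venous blood for antagonist activity at C-X-C chemokine receptor type 3 (Homo sapiens), read by flow cytometry, with a stated time of 30 min, in the presence of a further agent that is not named here; a lower number here means a stronger inhibitor, a higher number a weaker inhibitor. Within the data shown here, compound 2 `Cc1nc(C)n(CC(=O)N2CCN(c3sc(C(F)(F)F)nc3-c3nc4ccc(C5CCN(C)CC5)cc4[nH]3)C[C@H]2C)n1` gives 84.7 nM there, so that the one measured step, a 6.8-fold lower number from compound 1 to compound 2 (0.84 log units; beyond the scatter), concerns the group on the aromatic carbon of the shared core. Compound 3 `Cc1nn(CC(=O)N2CCN(c3sc(C(F)(F)F)nc3-c3nc4ccccc4[nH]3)C[C@H]2C)cc1CN(C)C` gives 330 nM; it stands second highest of the three numbers, nearest to compound 1 and within the scatter of it, and beyond the scatter above compound 2.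

Compound 4 `COC1CCN(CC(=O)N2CCN(c3sc(C(F)(F)F)nc3-c3nc4ccccc4[nH]3)C[C@H]2C)C1` is the next step. Compared with compound 3, the change is 3-methoxypyrrolidin-1-yl in place of 4-((dimethylamino)methyl)-3-methyl-1H-pyrazol-1-yl on a saturated chain carbon bound to a carbonyl carbon. Among the measured compounds shown here, this alteration sits on the saturated chain carbon bound to the carbonyl carbon, far from the aromatic carbon where the only measured step was taken. For the measured compounds named here, that step, a 6.8-fold lower number from compound 1 to compound 2 (0.84 log units; beyond the scatter), was modest, but it does not concern the same part of the molecule, so no measured step bears directly on the change from compound 3 to compound 4. The data give no basis to expect a step beyond the scatter in either direction in this assay; the estimate is therefore anchored on compound 3 with a wide range.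

For compound 4 the expected step is a 1.2-fold higher number from compound 3 to compound 4 (0.08 log units; within the scatter). Compound 4 is estimated at 400 nM, with a range from 130 nM to 1300 nM.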

Compound 4, half-maximal inhibitory concentration: 3380 nM
For compound 4 the middle estimate is 8.5-fold (0.93 log units) below the measured one; the whole stated range lies below it.
By their numbers in this assay, from the lowest: compound 2; then compounds 3 and 1 (each within the scatter of the next); then compound 4.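

In this assay, among these compounds, the saturated chain carbon bound to a carbonyl carbon proves to be a sensitive place: 3-methoxypyrrolidin-1-yl in place of 4-((dimethylamino)methyl)-3-methyl-1H-pyrazol-1-yl gives a 10-fold higher number from compound 3 to compound 4 (1.01 log units; beyond the scatter), a large step at a site where the earlier compounds offered no measured step at all. The change is not a single one, since a five-membered aromatic ring gives way to a five-membered non-aromatic ring, the dimethylamino group leaves and a methoxy group enters, so these compounds cannot assign the step to any one of these parts. Nothing measured here accounts for the size of the step.

On these data alone, it remains open whether a pyrrolidine carrying an amine in place of the methoxy group would stand nearer to compound 3 or to compound 4, and whether a pyrazole without its dimethylamino group would keep the number of compound 3. As far as these compounds go, it is equally open whether the step would keep its size on a core bearing the 1-methylpiperidin-4-yl group of compound 2.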